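Swapping the Linker Oxygen for a Carbon–Carbon Double Bond

A few compounds are considered here, and "the series" means these few. Any claim that something is new, unique, unknown or untested is made for them only; others in the source may bear on it.

Two compounds share one core and differ only in the group attached to an aromatic carbon. Compound 1 `Clc1ccc2[nH]c(SCc3ccccc3Cc3ccccc3)nc2c1` carries a benzyl group, and in an assay on isolated protein for inhibition of Indoleamine 2,3-dioxygenase 1 (Homo sapiens), with a stated time of 60 min, tested at 10 uM (on this read-out lower numbers stand for less inhibition and higher numbers for more inhibition at the one concentration tested (going by the name of the read-out)), compound 1 gives 46%. Compound 2 `Clc1ccc2[nH]c(SCc3ccccc3OCc3ccccc3)nc2c1` carries a benzyloxy group instead, and in this assay compound 2 gives 3%, the lowest of the two numbers measured. For the measured compounds named here, the single measured step, a number 43 percentage points lower from compound 1 to compound 2 (beyond the scatter), shows that inserting an oxygen into this linker is accompanied by a large drop in inhibition.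

Compound 3 `Clc1ccc2[nH]c(SCc3ccccc3/C=C/c3ccccc3)nc2c1` is the next member. Its change from compound 2 is 2-phenylethenyl in place of benzyloxy on an aromatic carbon. Like compound 1, compound 3 has no oxygen in this position, so the measured step is the only guide, though the new linker holds a double bond that neither measured compound has. A rise in this assay is therefore expected, roughly a number 27 percentage points higher from compound 2 to compound 3 (beyond the scatter), though with wide uncertainty. Compound 3 is estimated at 30%, within a range of 5% to 60%.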

Compound 3, a percentage reported as inhibition, at one concentration (the size of the read-out at that concentration, not a potency): -6%
Compound 3: middle estimate off by 36 percentage points, on the high side; measured number below the stated range.
By their numbers in this assay, from the lowest: compounds 3 and 2 (each within the scatter of the next); then compound 1.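

In this assay, 2-phenylethenyl in place of benzyloxy gives a number 9 percentage points lower from compound 2 to compound 3 (within the scatter), so a linker without oxygen does not by itself keep the inhibition seen with the benzyl group. Set against benzyl, the same 2-phenylethenyl group gives a number 52 percentage points lower from compound 1 to compound 3 (beyond the scatter). At this position, ortho to a large group, benzyl alone therefore stands apart from the other two groups, and the loss of inhibition cannot be pinned on the oxygen alone.

No measurement here explains why the benzyl group differs from the other two. Going by these compounds, it remains open whether 2-phenylethyl, which keeps the chain of 2-phenylethenyl without its double bond, would behave like benzyl or like 2-phenylethenyl, and how an amine in place of the linker oxygen would compare.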